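Oxolanyl to 2-methylfuranyl on the piperidine amide carbonyl

The source may report more compounds than this note shows. Statements on the series, on what has been measured and on what is new or still open speak of the compounds shown alone.

Compound 1 `O=C(Nc1ccc(C(F)(F)F)cc1)NC1CCN(C(=O)C2=COCC2)CC1` gives 3.37 in a physicochemical assay for lipophilicity, read by HPLC, with a stated time of 90 min, tested at 100 uM; a lower number here means a more polar compound, a higher number a more lipophilic compound
Compound 2 `O=C(Nc1ccc(C(F)(F)F)cc1)NC1CCN(C(=O)C2CCOC2)CC1` gives 3.16 in this assay

Compound 2 holds the lower of the two numbers, with compound 1 the nearest, the step of a number 0.21 log units lower from compound 1 to compound 2 (within the scatter). Compound 3 `Cc1occc1C(=O)N1CCC(NC(=O)Nc2ccc(C(F)(F)F)cc2)CC1` is not yet measured; it differs from compound 2 by 2-methylfuran-3-yl in place of oxolan-3-yl on a carbonyl carbon. Going by the values given here, the one measured step, a number 0.21 log units lower from compound 1 to compound 2 (within the scatter), exchanges two non-aromatic five-membered rings and is within the scatter; no measured step brings an aromatic ring onto this carbonyl carbon, so it bears only loosely on the change. The estimate for compound 3 is 3.9, range 3.5 to 4.3, an expected step of a number 0.74 log units higher from compound 2 to compound 3 (beyond the scatter) in this assay.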

Compound 3, partition coefficient: 4.19
Estimate against measurement, compound 3: 0.29 log units below; the range from low to high includes it.
By their numbers in this assay, from the lowest: compounds 2 and 1 (each within the scatter of the next); then compound 3.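

In this assay, going by these compounds alone, the change on this carbonyl carbon gives a number 1.03 log units higher from compound 2 to compound 3 (beyond the scatter) and a number 0.82 log units higher from compound 1 to compound 3 (beyond the scatter) as the first steps beyond the scatter. This position therefore does not read the same for every five-membered ring, as the two non-aromatic rings alone left unclear. No measurement shown accounts for the size of these steps.

As far as these compounds go, the aromatic ring and its methyl enter together in compound 3, so their separate shares stay open; plain furan-3-yl would divide them. From the compounds shown here alone, how a ring carrying an amine or a carboxylic acid would read also remains open.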